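Relocating the urea attachment on a bicyclic heteroaryl

A few compounds are considered here, and "the series" means these few. Any claim that something is new, unique, unknown or untested is made for them only; others in the source may bear on it.

Compound 3 `O=C(Nc1cccn2ccnc12)N1CCN(Cc2cccc(Oc3ccc(Cl)cc3)c2)CC1` is the weaker of the two compounds with a numerical result in an assay on isolated protein for inhibition of Fatty-acid amide hydrolase 1 (Homo sapiens), with a stated time of 60 min (on this read-out higher numbers stand for weaker inhibition and lower numbers for stronger inhibition), giving 310 nM. Compound 1 `O=C(Nc1noc2cnccc12)N1CCN(Cc2cccc(Oc3ccc(Cl)cc3)c2)CC1` gives 0.5 nM in this assay. Compound 2 `O=C(Nc1cn2ccccc2n1)N1CCN(Cc2cccc(Oc3ccc(Cl)cc3)c2)CC1` reaches only the limit of this assay, > 10000 nM, and so returns no number (the limit of > 10000 nM in this assay, at which 1 of the 3 values shown sits). The change from compound 3 to compound 4 `O=C(Nc1cccc2nccn12)N1CCN(Cc2cccc(Oc3ccc(Cl)cc3)c2)CC1` is a group of 9 heavy atoms (7 carbon, 2 nitrogen; one five-membered aromatic ring with 2 hetero atoms, one six-membered aromatic ring with 1 hetero atom) in place of a group of 9 heavy atoms (7 carbon, 2 nitrogen; one five-membered aromatic ring with 2 hetero atoms, one six-membered aromatic ring with 1 hetero atom), on an amide-type nitrogen; the two compounds share every atom and differ only in how the bicyclic group is joined to the urea nitrogen.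

Within the data shown here, two measured steps concern the same place. The step of a 620-fold higher number from compound 1 to compound 3 (2.79 log units; beyond the scatter) and the step of an at least 20000-fold higher number from compound 1 to compound 2 (4.30 log units; beyond the scatter) show that exchanging one bicyclic heteroaryl for another on this urea nitrogen can shift the read-out by a large margin, and the step of an at least 32-fold lower number from compound 2 to compound 3 (1.50 log units; beyond the scatter) shows that even rejoining the same atoms differently carries a large consequence. Since compound 4 again rearranges the same atoms, a large step is expected, and the direction taken here is toward a higher number. Compound 4 is therefore expected to give 3000 nM in this assay, within 600 nM to 15000 nM, which means an expected step of a 9.7-fold higher number from compound 3 to compound 4 (0.99 log units; beyond the scatter).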

Compound 4, half-maximal inhibitory concentration: 2.7 nM
For compound 4 the middle estimate is 1100-fold (3.05 log units) above the measured one, outside the stated range (below it).
By their numbers in this assay, from the lowest: compound 1; then compound 4; then compound 3. At a limit, above all of these: compound 2.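

With the atoms unchanged and only the joining of the bicyclic group to the amide-type nitrogen altered, the read-out in this assay shows a 110-fold lower number from compound 3 to compound 4 (2.06 log units; beyond the scatter), and the comparison with the compound at the limit gives an at least 3700-fold lower number from compound 2 to compound 4 (3.56 log units; beyond the scatter), so the mode of attachment alone can separate weak from strong inhibition in this series. The remaining gap to the oxygen-containing bicyclic group is much smaller, at a 5.4-fold higher number from compound 1 to compound 4 (0.73 log units; beyond the scatter), which is modest but beyond the scatter and shows that a group of 7 carbon and 2 nitrogen atoms can come close to that result when it is joined as in compound 4. Compound 2 has a limit and not a number, so its step gives only a bound: the limit of > 10000 nM in this assay, at which 1 of the 4 values shown sits.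

The compounds shown do not reveal what underlies these differences, since the joining changes while the counted atoms, donors and acceptors stay the same. On these data alone, it also remains open whether a methyl group or a fluorine on the bicyclic group of compound 4 would preserve its result, or whether the same order would hold with a fluorine in place of the chlorine on the shared remainder.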